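The source may hold more compounds than are shown below. What is called first, only, known or untested is meant among the compounds shown, and "the series" means these compounds.

Measured compounds:
compound 1, `O=C(O)CCc1ccc2[nH]c(-c3ccc(Cl)cc3F)cc2c1` — > 25 nM
compound 2, `Cc1c(Cl)cccc1-c1cc2cc(CCC(=O)O)ccc2[nH]1` — 0.38 nM

Two compounds built on one shared core have been run in a functional assay on CHO cells for agonist activity at Free fatty acid receptor 1 (Homo sapiens), read by a luciferase reporter, with a stated time of 24 h; on this read-out lower numbers stand for an effect already at smaller amounts and higher numbers for an effect only at larger amounts of compound. Compound 1 gives > 25 nM in this assay, and that value is only a limit of the assay, not a number. Compound 2 gives 0.38 nM in this assay. Where compound 1 stands is therefore told only by the limit of > 25 nM in this assay, at which 1 of the 2 values shown sits, so the two values cannot be set against each other as a measured step.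

Compound 3, `O=C(O)CCc1ccc2[nH]c(-c3ccc(Cl)cc3C(F)(F)F)cc2c1`, differs from compound 1 in one place: trifluoromethyl in place of fluoro on an aromatic carbon. Among the compounds with values here, no measured pair of compounds shows a change of this kind, so the size of the step has no precedent here; with compound 1 fixed only at a limit, even its direction remains open. Compound 3 is expected to land near 15 nM, with a range from 1 nM to 100 nM. That expectation corresponds to a step of an at least 1.6-fold lower number from compound 1 to compound 3 (0.22 log units; that floor lies within the scatter).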

Compound 3, half-maximal effective concentration: > 25 nM
Compound 3: a limit, no number; the forecaster's own chance of this, stated with the estimate: 35%; middle value at least 1.6-fold (0.22 log units) away from the limit.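

Compound 3, like compound 1, stands only at a limit in this assay, not at a number, so no step between compound 1 and compound 3 can be read: the limit of > 25 nM in this assay, at which 2 of the 3 values shown sit.

The compounds shown leave open whether trifluoromethyl in place of fluoro on an aromatic carbon changes the read-out at all, and in which direction.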